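The source may report more compounds than this note shows. Statements on the series, on what has been measured and on what is new or still open speak of the compounds shown alone.

Measured in a physicochemical assay for lipophilicity; on this read-out lower numbers stand for lower lipophilicity and higher numbers for higher lipophilicity:
- compound 1 `CC(C)(C)OC(=O)NC[C@H]1CC[C@H](CNC(=O)c2cc(N3CCC(CCN4CC(O)C4)CC3)nc3ccccc23)CC1`: 3.6
- compound 2 `Cc1noc(C)c1-c1cc(C(=O)NC[C@H]2CC[C@H](CNC(=O)OC(C)(C)C)CC2)c2ccccc2n1`: 5

Compound 2 stands highest of the two, with compound 1 lower by a gap beyond the scatter. Compound 3 `CC(C)(C)OC(=O)NC[C@H]1CC[C@H](CNC(=O)c2cc(N3CCC(CCO)CC3)nc3ccccc23)CC1` is not yet measured in this assay. It carries 4-(2-hydroxyethyl)piperidin-1-yl in place of 3,5-dimethyl-1,2-oxazol-4-yl on an aromatic carbon. The expected step is downward and beyond the scatter (a number 0.60 log units lower from compound 2 to compound 3 (beyond the scatter)). Going by the values given here, this expectation rests on compound 1 (3.6), the closer structural neighbour, though no measured pair isolates this change. For compound 3 the estimated value is 4.4 (expected range 3.9 to 4.9).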

Compound 3, distribution coefficient: 4.5
Beside the measured number, compound 3's estimate is 0.10 log units below it; the range from low to high includes it.
By their numbers in this assay, from the lowest: compound 1; then compound 3; then compound 2.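

In this assay, going by these compounds alone, 4-(2-hydroxyethyl)piperidin-1-yl in place of 3,5-dimethyl-1,2-oxazol-4-yl on the aromatic carbon next to the ring nitrogen gives a number 0.50 log units lower from compound 2 to compound 3 (beyond the scatter), a first direct reading of a change at this position. Hydroxy in place of 3-hydroxyazetidin-1-yl on the saturated chain carbon gives a number 0.90 log units higher from compound 1 to compound 3 (beyond the scatter), so the end of that chain also moves the read-out. No available evidence bears on the reason for either step.

Whether the piperidine ring or its hydroxy accounts for the first step stays open. Also open, on these data alone, is how an amine or a carboxylic acid at the chain end would compare.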